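A few compounds are considered here, and "the series" means these few. Any claim that something is new, unique, unknown or untested is made for them only; others in the source may bear on it.

Measured so far in an assay on COS-7 cells for agonist activity at Free fatty acid receptor 1 (Homo sapiens), read by scintillation counting and inositol phosphate accumulation, with a stated time of 90 min; a lower number here means that less compound is needed, a higher number that more compound is needed for the effect:
compound 1 `Cc1cc(=O)oc2cc(OCc3nc(N)nc(Nc4ccc(Cl)c(Cl)c4)n3)ccc12`, 780 nM
compound 2 `Cc1cc(=O)oc2cc(OCc3nc(N)nc(NCc4ccc(F)cc4)n3)ccc12`, 7820 nM
compound 3 `Cc1ccc(Nc2nc(N)nc(COc3cc(F)cc(N4CCCC4=O)c3)n2)cc1Cl`, 1800 nM

In this assay compound 3 stands second highest of the three numbers: compound 1 sits at a lower number and compound 2 at a higher one, both beyond the scatter. Compound 4 `Cc1ccc(Nc2nc(N)nc(COc3cc(Cl)cc(N4CCCC4=O)c3)n2)cc1Cl` differs from compound 3 by chloro in place of fluoro on an aromatic carbon. For the measured compounds named here, the only measured step, a 10-fold higher number from compound 1 to compound 2 (1.00 log units; beyond the scatter), exchanges a whole substituent on a ring nitrogen and says nothing about swapping one halogen for another on an aromatic carbon; no measured pair tests chloro against fluoro. Therefore no step beyond the scatter is expected. Compound 4 is estimated at 1500 nM, with a range from 600 nM to 4000 nM. The expected step of a 1.2-fold lower number from compound 3 to compound 4 (0.08 log units; within the scatter) lies within the scatter.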

Compound 4, half-maximal effective concentration: 160 nM
For compound 4 the middle estimate is 9.4-fold (0.97 log units) above the measured one; measured number below the stated range.
By their numbers in this assay, from the lowest: compound 4; then compound 1; then compound 3; then compound 2.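

In this assay, chloro in place of fluoro on an aromatic carbon, meta to a 2-oxopyrrolidin-1-yl group, gives a large change (an 11-fold lower number from compound 3 to compound 4 (1.05 log units; beyond the scatter)), so a single heavy atom at this position shifts the number beyond the scatter. Among the earlier compounds, only the exchange of a whole substituent on a nitrogen had given a step of similar size (a 10-fold higher number from compound 1 to compound 2 (1.00 log units; beyond the scatter)). Nothing given here explains the difference between these two halogens. Going by these compounds, whether bromo, methyl or methoxy at this position would go further or reverse the step remains open. So does whether chloro would have the same effect with a group other than 2-oxopyrrolidin-1-yl on the ring.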